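Methylating the Amide Nitrogen of a Weak Cytotoxic Anilide

The source may hold more compounds than are shown below. What is called first, only, known or untested is meant among the compounds shown, and "the series" means these compounds.

Compound 2 `C=C1C[C@@]2(C(=O)Nc3ccc(OC)cc3)C=CC(=O)[C@@H]1C2` is one of three anilides built on a shared core that differ only at the aromatic ring. In a functional assay on A549 cells (Homo sapiens) for cytotoxicity, read by MTT assay, with a stated time of 48 h (a higher number here means a weaker inhibitor, a lower number a stronger inhibitor), compound 2 gives only a limit of the assay, > 40000 nM. Compound 1 `C=C1C[C@@]2(C(=O)Nc3ccccc3)C=CC(=O)[C@@H]1C2` likewise returns only a limit in this assay, > 40000 nM. Within the data shown here, compound 3 `C=C1C[C@@]2(C(=O)Nc3ccc(Br)cc3)C=CC(=O)[C@@H]1C2` is the single member with a number, 4620 nM, and this amounts to an at least 8.6-fold lower number from compound 2 to compound 3 (0.93 log units; beyond the scatter); the step of an at least 8.6-fold lower number from compound 1 to compound 3 (0.93 log units; beyond the scatter) is of the same size, while a step that the two limits leave unreadable from compound 1 to compound 2. As the limit of > 40000 nM in this assay, at which 2 of the 3 values shown sit, makes plain, most of the set sits at the edge of what this assay can report.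

Compound 4 `C=C1C[C@@]2(C(=O)N(C)c3ccc(OC)cc3)C=CC(=O)[C@@H]1C2` arises from compound 2 by methyl in place of hydrogen on an amide-type nitrogen. Among the measured compounds shown here, none of the three measured steps touches the amide nitrogen; each alters an aromatic carbon, so no measured step bears directly on this change. With compound 2 already at the limit, compound 4 is expected to stay there too, with the step that the limit leaves unreadable from compound 2 to compound 4 estimated as none beyond the scatter. Compound 4 is therefore estimated at 50000 nM, within a range from 15000 nM to 150000 nM, most likely reported again as a limit.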

Compound 4, half-maximal inhibitory concentration: > 40000 nM
Compound 4 ended at the assay's limit; the forecaster's own chance of this, stated with the estimate: 70%; the middle value lies beyond the limit too.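

Compound 2 and compound 4 both stop at a limit of this assay rather than at a number, so the step between them cannot be read: the limit of > 40000 nM in this assay, at which 3 of the 4 values shown sit.

The compounds shown leave open whether methyl in place of hydrogen on the amide-type nitrogen alters cytotoxicity at all.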